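Notes: 3,4-dihydroxyphenyl to 4-chlorophenyl

The source may report more compounds than this note shows. Statements on the series, on what has been measured and on what is new or still open speak of the compounds shown alone.

Values in a functional assay on cells (Erythrocyte, Homo sapiens) for inhibition, read by spectrophotometry and hemolysis, with a stated time of 10 min; a higher number here means a weaker inhibitor, a lower number a stronger inhibitor:
- compound 1 `O=C(CCc1nc2ccccc2c(=O)[nH]1)N/N=C/c1ccc(O)c(O)c1` gives 255000000 nM
- compound 2 `O=C(CCCc1nc2ccccc2c(=O)[nH]1)N/N=C/c1cc(O)c(O)c(O)c1` gives 183000000 nM
- compound 3 `COc1cc(/C=N/NC(=O)CCc2nc3ccccc3c(=O)[nH]2)cc(OC)c1OC` gives 682000000 nM

Compound 1 stands second highest of the three numbers, within the scatter of compound 2 and below compound 3 by a gap beyond the scatter. The next compound is compound 4 `O=C(CCc1nc2ccccc2c(=O)[nH]1)N/N=C/c1ccc(Cl)cc1`, with 4-chlorophenyl in place of 3,4-dihydroxyphenyl on a carbon with a double bond to nitrogen. No measured pair differs in one place only, so the size of this step is not shown directly. A moderate rise in this assay, toward a weaker inhibitor, is expected, since compound 3 without hydroxy groups gives 682000000 nM. The expected change is a 2.2-fold higher number from compound 1 to compound 4 (0.33 log units; beyond the scatter). For compound 4 the estimated value is 550000000 nM, with an expected range of 220000000 nM to 1400000000 nM.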

Compound 4, half-maximal inhibitory concentration: 84000000 nM
Compound 4: middle estimate off by 6.5-fold (0.82 log units), on the high side; measured number outside the range, below it.
By their numbers in this assay, from the lowest: compound 4; then compounds 2 and 1 (each within the scatter of the next); then compound 3.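

In this assay, 4-chlorophenyl in place of 3,4-dihydroxyphenyl on the carbon with a double bond to nitrogen gives a 3.0-fold lower number from compound 1 to compound 4 (0.48 log units; beyond the scatter), so a stronger inhibitor at this position does not need the two hydroxy groups. The change removes both hydroxy groups and adds chlorine together, so their separate shares cannot be read. No measurement at hand explains the step. Still open, on these data alone, is how plain phenyl or 4-bromophenyl would read at this position. Also open, as far as these compounds go, is whether 4-chlorophenyl gives a similar step on the longer chain of compound 2.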